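A few compounds are considered here, and "the series" means these few. Any claim that something is new, unique, unknown or untested is made for them only; others in the source may bear on it.

Measured so far:
compound 1, `CC[C@H](CCn1cncn1)c1ccccc1`: 97.7 ug/mL
compound 2, `CCCC[C@H](CCn1cncn1)c1ccccc1`: 50.2 ug/mL

For the measured compounds named here, in an ADME assay on HEp-2 cells (Homo sapiens) for cytotoxicity, read by MTT assay, with a stated time of 3 days (a lower number here means that less compound is tolerated, a higher number that more compound is tolerated), compound 2 gives the lowest of the two numbers measured so far, but its only neighbour, compound 1, sits within the scatter of it: a 1.9-fold lower number from compound 1 to compound 2 (0.29 log units; within the scatter). Compound 3, `CCCC[C@H](CCn1cncn1)c1ccc(C)cc1`, has not yet been measured in this assay. It differs from compound 2 by methyl in place of hydrogen on an aromatic carbon.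

Going by the values given here, no measured step changes a substituent on the aromatic ring; the single step on record, from compound 1 to compound 2, concerns the saturated chain and was itself within the scatter. It therefore gives no direct guide, and only a general sense that small additions of carbon have so far left the number close to where it was. Among the compounds with values here, on that basis no step beyond the scatter is expected for compound 3 in this assay; if anything, a slightly lower number would be in line with the one step seen.

The estimate for compound 3 in this assay is 40 ug/mL, with a range of 20 ug/mL to 80 ug/mL, which corresponds to an expected step of a 1.3-fold lower number from compound 2 to compound 3 (0.10 log units; within the scatter).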

Compound 3, half-maximal cytotoxic concentration: 23.7 ug/mL
Compound 3: the middle estimate sits 1.7-fold (0.23 log units) above what was measured; the range from low to high includes it.
By their numbers in this assay, from the lowest: compound 3; then compounds 2 and 1 (each within the scatter of the next).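

In this assay, for the compounds shown here, methyl in place of hydrogen on an aromatic carbon, para to a large group, is the first change on the six-membered aromatic ring of carbon only, and it gives a modest step beyond the scatter (a 2.1-fold lower number from compound 2 to compound 3 (0.33 log units; beyond the scatter)). Going by these compounds alone, the only earlier step, ethyl in place of hydrogen on the saturated chain (a 1.9-fold lower number from compound 1 to compound 2 (0.29 log units; within the scatter)), stayed within the scatter, so this ring carbon is the first place where a single change moves the number past it, and here a single added carbon is enough. Nothing measured here bears on the reason for this step.

The compounds shown cannot tell whether the step is particular to methyl or would also appear with a chlorine atom, a methoxy group, an amine or a carboxylic acid on the same ring carbon. Within the data shown here, they also leave open whether the same methyl gives a step of similar size on the shorter chain of compound 1, or whether a longer chain in place of the one in compound 2 would add to it.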